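An Ester on the Phenyl Ring of Compound 2

The source may report more compounds than this note shows. Statements on the series, on what has been measured and on what is new or still open speak of the compounds shown alone.

Measured compounds:
compound 1, `NS(=O)(=O)NCC1CCN(c2cc(-c3ccccc3)ncn2)CC1`: > 100000 nM in a functional assay on HT-29 cells (Homo sapiens) for antiproliferative activity, read by sulforhodamine B assay, with a stated time of 48 h (a lower number here means a stronger inhibitor of growth, a higher number a weaker inhibitor of growth), a limit rather than a number
compound 2, `NS(=O)(=O)NCCC1CCN(c2cc(-c3ccccc3)ncn2)CC1`: 66500 nM in this assay

For the measured compounds named here, compound 2 holds the only number among the two values shown. Compound 1 sits at the limit of > 100000 nM in this assay, at which 1 of the 2 values shown sits. Going by the values given here, the one measured step, an at least 1.5-fold lower number from compound 1 to compound 2 (0.17 log units; that floor lies within the scatter), concerns the chain that carries the sulfamoylamino group and does not touch the phenyl ring.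

Compound 3, `CCOC(=O)c1ccc(-c2cc(N3CCC(CCNS(N)(=O)=O)CC3)ncn2)cc1`, differs from compound 2 by ethoxycarbonyl in place of hydrogen on an aromatic carbon. Among the compounds with values here, no measured step bears on a change of this kind, so no direction can be read from the data. Compound 3 is therefore expected to stay close to compound 2, with the step of a 1.3-fold lower number from compound 2 to compound 3 (0.12 log units; within the scatter) lying within the scatter. The estimate for compound 3 in this assay is 50000 nM, ranging from 15000 nM to 150000 nM.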

Compound 3, concentration for 50% growth inhibition: 6800 nM
The estimate for compound 3 lay 7.4-fold (0.87 log units) above the measured number; the whole stated range lies above it.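

Ethoxycarbonyl on an aromatic carbon of the phenyl ring, para to a large group, gives in this assay a 9.8-fold lower number from compound 2 to compound 3 (0.99 log units; beyond the scatter), and this step lies beyond the scatter. For the compounds shown here, the earlier compounds differed only in the chain that carries the sulfamoylamino group, so compound 3 is the first to show that a change on this ring can move the number in the direction of stronger inhibition of growth. Nothing among the measurements shown accounts for the size of this step.

From the compounds shown here alone, it remains open whether the ester itself matters or whether any group at this carbon would do, which a carboxylic acid, an amide or a methyl group there could help to settle. Also open, going by these compounds, is whether ethoxycarbonyl would have a similar effect on the chain of compound 1.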